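A few compounds are considered here, and "the series" means these few. Any claim that something is new, unique, unknown or untested is made for them only; others in the source may bear on it.

Measured compounds:
- compound 1, `CC(C)N1CCN(Cc2csc(N)c2C(=O)c2ccc(Cl)cc2)CC1`: 3.6%
- compound 2, `Nc1scc(CN2CCN(c3ccc(F)cc3Cl)CC2)c1C(=O)c1ccc(Cl)cc1`: -6.2%
- compound 3, `Nc1scc(CN2CCN(C3CCCCCC3)CC2)c1C(=O)c1ccc(Cl)cc1`: 13%

These three share one core and differ only in the group carried on an amine nitrogen in a ring. In a functional assay on CHO cells with adenosine receptor A1 (Homo sapiens) as the target, read by cAMP accumulation and immunoassay, with a stated time of 6 min, tested at 0.1 uM (a higher number here means a weaker effect of the compound at the concentration tested, a lower number a stronger effect), compound 3 gives the highest of the three numbers; its gap to compound 1 lies within the scatter, while its gap to compound 2 lies beyond it.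

Compound 4, `Nc1scc(CN2CCN(c3ccccc3F)CC2)c1C(=O)c1ccc(Cl)cc1`, has not yet been measured. It differs from compound 3 in this way: 2-fluorophenyl in place of cycloheptyl on an amine nitrogen in a ring.

Among the measured compounds shown here, two measured steps bear on this change. The step of a number 19.2 percentage points higher from compound 2 to compound 3 (beyond the scatter) compares an aromatic group with cycloheptyl at the same place, and the step of a number 9.8 percentage points lower from compound 1 to compound 2 (within the scatter) shows that compound 2 and compound 1 are not separated beyond the scatter. Because the step of a number 19.2 percentage points higher from compound 2 to compound 3 (beyond the scatter) was beyond the scatter, the reverse move from cycloheptyl to an aromatic group is expected to lower the number by a modest amount, so the step of a number 17 percentage points lower from compound 3 to compound 4 (beyond the scatter) is expected. Compound 4 is therefore estimated at -4%, with a range from -18% to 10%.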

Compound 4, a percentage reported as activity, at one concentration (the size of the read-out at that concentration, not a potency): -1%
The estimate for compound 4 lay 3 percentage points below the measured number, within the range that was stated.
By their numbers in this assay, from the lowest: compounds 2, 4, 1 and 3 (each within the scatter of the next, the first and the last beyond it).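

In this assay, swapping cycloheptyl for 2-fluorophenyl on this ring nitrogen gives a number 14 percentage points lower from compound 3 to compound 4 (beyond the scatter) and so shows that a second aromatic group also stands apart from cycloheptyl. The two aromatic groups cannot be told apart, since the change from 2-chloro-4-fluorophenyl to 2-fluorophenyl gives only a number 5.2 percentage points higher from compound 2 to compound 4 (within the scatter) and the halogen pattern on the ring has no readable effect in this pair. Compound 1 goes against any simple split between aromatic and non-aromatic groups, as a number 4.6 percentage points lower from compound 1 to compound 4 (within the scatter) leaves isopropyl level with 2-fluorophenyl, so the separation holds only against cycloheptyl.

From the compounds shown here alone, whether a plain phenyl or a cyclohexyl at this nitrogen would group with cycloheptyl or with the aromatic compounds remains open. Nothing measured here accounts for the gap between cycloheptyl and the aromatic groups.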